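A Benzyl Swap on a Shared Core, Estimated

A few compounds are considered here, and "the series" means these few. Any claim that something is new, unique, unknown or untested is made for them only; others in the source may bear on it.

Compound 1 `Nc1cc(N)c2nc(-c3ccccc3)c(NCc3ccc(Cl)c(Cl)c3)nc2c1` gives 72400 nM in a functional assay on TK-10 cells (Homo sapiens) for inhibition, read by sulforhodamine B assay, with a stated time of 48 h; a higher number here means that more compound is tolerated, a lower number that less compound is tolerated.
Compound 2 `CCOC(=O)[C@H](CCC(=O)O)NC(=O)c1ccc(Sc2nc3cc(N)cc(N)c3nc2-c2ccccc2)cc1` gives < 100000 nM in this assay, which is a limit of the assay and not a number.

Compound 1 holds the only number shown in this assay; the other reading is a limit. For compound 2 the reading is the limit of < 100000 nM in this assay, at which 1 of the 2 values shown sits, so it is known only as far as that limit. Compound 3 `COc1ccc(CNc2nc3cc(N)cc(N)c3nc2-c2ccccc2)cc1` has not yet been measured in this assay. It differs from compound 1 in one place: 4-methoxyphenyl in place of 3,4-dichlorophenyl on a saturated chain carbon bound to a nitrogen on an aromatic ring. Among the measured compounds shown here, no step between two measured compounds shares this change, so nothing measured shows how such a swap moves the read-out, and the shared core with its phenyl group and both amino groups is kept unchanged. For the measured compounds named here, with no pair to lean on, compound 3 is expected to sit close to compound 1, with a step of a 1.1-fold higher number from compound 1 to compound 3 (0.04 log units; within the scatter) that is expected to stay within the scatter of repeated measurements. The estimate for compound 3 in this assay is 80000 nM, expected to fall between 30000 nM and 200000 nM; a limit rather than a number would not be surprising.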

Compound 3, concentration lethal to 50% of the cells: < 100000 nM
Compound 3: a limit, no number; the forecaster's own chance of this, stated with the estimate: 40%; the middle value is on the limit's open side.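

In this assay compound 3 gives < 100000 nM and this is a limit of the assay, not a number. Among the compounds shown here, no step from compound 1 to compound 3 can be read, because the result for compound 3 is a limit: the limit of < 100000 nM in this assay, at which 2 of the 3 values shown sit. The compounds shown leave open whether 4-methoxybenzyl in place of 3,4-dichlorobenzyl on the shared core moves the read-out at all, and how far.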